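The compounds below may be only part of what the source reports. "The series", "measured", "known", "first", "only" and "open" are said of these compounds alone.

The set concerns three compounds on one shared core, all tested in a functional assay on MV4-11 cells (Homo sapiens) for antiproliferative activity, read by resazurin assay, with a stated time of 72 h; a higher number here means a weaker inhibitor, a lower number a stronger inhibitor. Compound 1 `N#Cc1c(-c2ccco2)nc2c(c(-c3ccccc3)nn2-c2ccccc2)c1-c1ccc(O)cc1` gives 13800 nM. Compound 2 `COc1cc(-c2c(C#N)c(-c3ccco3)nc3c2c(-c2ccccc2)nn3-c2ccccc2)ccc1O` gives 35300 nM, and compound 3 `N#Cc1c(-c2cccs2)nc2c(c(-c3ccccc3)nn2-c2ccccc2)c1-c1ccc(O)cc1` gives 34200 nM. Compound 2 thus carries the highest number of the three, though its gap to compound 3 lies within the scatter, so no order between those two can be drawn, whereas the step of a 2.6-fold higher number from compound 1 to compound 2 (0.41 log units; beyond the scatter) sets compound 2 beyond the scatter from compound 1. Compound 4 `COc1cc(-c2c(C#N)c(-c3ccccc3)nc3c2c(-c2ccccc2)nn3-c2ccccc2)ccc1O` differs from compound 2 in one place: phenyl in place of furan-2-yl on an aromatic carbon. Of the measured steps, a 2.5-fold higher number from compound 1 to compound 3 (0.39 log units; beyond the scatter) bears most directly on this change, as it also exchanges the furan-2-yl group at that site for another ring and gave a modest weakening. The step of a 2.6-fold higher number from compound 1 to compound 2 (0.41 log units; beyond the scatter) concerns a different site and says nothing about a ring exchange. For the measured compounds named here, no measured pair shows a phenyl in that place. On this basis a modest weakening, or none beyond the scatter, is expected for the ring exchange, the step from compound 2 to compound 4 being estimated as a 1.4-fold higher number from compound 2 to compound 4 (0.15 log units; within the scatter). Compound 4 is accordingly expected to give about 50000 nM in this assay, within a range from 20000 nM to 120000 nM.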

Compound 4, half-maximal inhibitory concentration: > 50000 nM
Compound 4: a limit, no number; the forecaster's own chance of this, stated with the estimate: 20%; the middle value lies on the limit itself.
By their numbers in this assay, from the lowest: compound 1; then compounds 3 and 2 (each within the scatter of the next). At a limit, above all of these: compound 4.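

In this assay compound 4 returns a limit and not a number: the limit of > 50000 nM in this assay, at which 1 of the 4 values shown sits. On the aromatic carbon next to the ring nitrogen and ortho to a cyano group, phenyl in place of furan-2-yl reads as an at least 1.4-fold higher number from compound 2 to compound 4 (0.15 log units; that floor lies within the scatter), so the floor of this step does not by itself separate the two compounds, and how much weaker compound 4 may be cannot be told. Even so, the result shows that the six-membered aromatic ring of carbon only brought no strengthening at this position on the background carrying the 4-hydroxy-3-methoxyphenyl group, and together with a 2.5-fold higher number from compound 1 to compound 3 (0.39 log units; beyond the scatter) it means that neither ring exchange shown here lowered the number, leaving furan-2-yl the better of the groups compared at this site.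

The compounds shown leave open where compound 4 truly lies beyond its limit and whether phenyl would behave in the same way on the core of compound 1, which lacks the methoxy group. They also leave open whether a non-aromatic group at this place, such as an amine or a short alkyl chain, would give a lower number than furan-2-yl.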